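Cyclohexyl for pyrimidinyl on the piperazine of compound 2

The source may hold more compounds than are shown below. What is called first, only, known or untested is meant among the compounds shown, and "the series" means these compounds.

Of the compounds shown here, two have been measured in a functional assay on HeLa cells (Homo sapiens) for antiproliferative activity, read by CCK-8 assay, with a stated time of 72 h, tested at 2 uM; a lower number here means a weaker effect, a higher number a stronger effect of the compound at the concentration tested. Compound 1 `Cc1ccc(N2CCN(C(=S)SCc3ccc(C(=O)Nc4ccccc4N)cc3)CC2)cc1` gives 25.3% there, and compound 2 `Nc1ccccc1NC(=O)c1ccc(CSC(=S)N2CCN(c3ncccn3)CC2)cc1` gives 52.2%, the higher of the two numbers shown. Among the compounds with values here, the one step between them, a number 26.9 percentage points higher from compound 1 to compound 2 (beyond the scatter), came from the exchange of 4-methylphenyl for pyrimidin-2-yl on an amine nitrogen in a ring. Compound 3 `Nc1ccccc1NC(=O)c1ccc(CSC(=S)N2CCN(C3CCCCC3)CC2)cc1` has not yet been measured; it differs from compound 2 by cyclohexyl in place of pyrimidin-2-yl on an amine nitrogen in a ring. Within the data shown here, no measured step tries this exchange, so the only guide is that the single change at the same place moved this assay by a modest amount beyond the scatter. The direction cannot be read from one step; the expected change is therefore a moderate fall, a number 12.2 percentage points lower from compound 2 to compound 3 (beyond the scatter), with wide uncertainty. Compound 3 is estimated at 40%, expected to lie between 18% and 62%.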

Compound 3, a percentage reported as inhibition, at one concentration (the size of the read-out at that concentration, not a potency): 30.6%
Compound 3: the middle estimate sits 9.4 percentage points above what was measured; the measured number falls inside the stated range.
By their numbers in this assay, from the lowest: compounds 1 and 3 (each within the scatter of the next); then compound 2.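

In this assay the position on the amine nitrogen now has a second replacement for pyrimidin-2-yl, and cyclohexyl gives a number 21.6 percentage points lower from compound 2 to compound 3 (beyond the scatter) in the same direction as the earlier exchange, so among these three groups only pyrimidin-2-yl goes with the higher number. Between the two lower compounds the exchange of 4-methylphenyl for cyclohexyl gives a number 5.3 percentage points higher from compound 1 to compound 3 (within the scatter) and thus no order, which shows that an aromatic ring of carbon and a non-aromatic ring of carbon do not separate here.

As far as these compounds go, whether pyridin-2-yl, plain phenyl or piperidin-4-yl on this nitrogen would stay near compound 2 or near compound 3 remains open, so the feature of pyrimidin-2-yl that counts cannot be named from these compounds. Nothing measured here explains why the numbers differ.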